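The compounds below may be only part of what the source reports. "The series", "measured", "known", "first", "only" and "open" are said of these compounds alone.

In a functional assay on ECa-109 cells (Homo sapiens) for antiproliferative activity, read by MTT assay, with a stated time of 48 h (on this read-out higher numbers stand for weaker inhibition and lower numbers for stronger inhibition), compound 1 (`Cn1cc(C2=C(c3nn(CCCN4CCCCC4)c4ncccc34)C(=O)N(c3ccc(Cl)cc3)C2=O)c2ccccc21`) gives > 100000 nM, which is a limit of the assay and not a number. Compound 1 therefore stands at the limit of > 100000 nM in this assay, at which 1 of the 3 values shown sits. The other two measured compounds give numbers: compound 2 (`Cn1cc(C2=C(c3nn(CCCN4CCCCC4)c4ncccc34)C(=O)N(c3ccccn3)C2=O)c2ccccc21`) gives 7300 nM, and compound 3 (`CN(C)CCCn1nc(C2=C(c3cn(C)c4ccccc34)C(=O)N(c3ccccc3)C2=O)c2cccnc21`) gives 5840 nM, two values within the scatter of each other.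

The step followed here leads from compound 1 to compound 4 (`Cn1cc(C2=C(c3nn(CCCN4CCCCC4)c4ncccc34)C(=O)NC2=O)c2ccccc21`), with this structural change: hydrogen in place of 4-chlorophenyl on an amide-type nitrogen in a ring. Hydrogen thus takes the place of 4-chlorophenyl on an amide-type nitrogen in a ring.

For the measured compounds named here, one measured step bears directly on this change, as it replaces the same group at the same place: an at least 13-fold lower number from compound 1 to compound 2 (1.13 log units; beyond the scatter). Going by the values given here, that step is large and beyond the scatter, but it brings in pyridin-2-yl rather than hydrogen, and no measured compound carries hydrogen there. Compound 2, with 7300 nM, therefore supports the expectation of a large step towards a lower number in this assay, though with wide uncertainty. The expected step is an at least 8.3-fold lower number from compound 1 to compound 4 (0.92 log units; beyond the scatter). For compound 4, the estimated value is 12000 nM, with an expected range from 2500 nM to 60000 nM.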

Compound 4, half-maximal inhibitory concentration: 42300 nM
Estimate against measurement, compound 4: 3.5-fold (0.55 log units) below, within the range that was stated.
By their numbers in this assay, from the lowest: compounds 3 and 2 (each within the scatter of the next); then compound 4. At a limit, above all of these: compound 1.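

With only the amide hydrogen on this nitrogen, this assay shows an at least 2.3-fold lower number from compound 1 to compound 4 (0.37 log units; beyond the scatter), so removing the 4-chlorophenyl group altogether is enough to bring the compound back from the limit to a measured number. Hydrogen does not match pyridin-2-yl at the same place, however, with a 5.8-fold higher number from compound 2 to compound 4 (0.76 log units; beyond the scatter), which puts hydrogen between the two ring groups and shows that this position can move the read-out in either direction relative to the unsubstituted nitrogen. The size of the first step is only a bound, because compound 1 stands at a limit of the assay and not at a number: the limit of > 100000 nM in this assay, at which 1 of the 4 values shown sits.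

Going by these compounds, it stays open whether the lower number of compound 2 belongs specifically to pyridin-2-yl or would also appear with pyridin-3-yl, a methyl group or a benzyl group on this nitrogen. Compound 3 carries a phenyl group here but also differs in its side chain, so it cannot settle how an unsubstituted phenyl ring compares with 4-chlorophenyl, and the effect of the chlorine on this ring remains unresolved.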